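Swapping the 3,4-dichlorophenyl group of compound 3

The compounds below may be only part of what the source reports. "The series", "measured", "known", "first", "only" and "open" are said of these compounds alone.

In a functional assay on Jurkat cells (Homo sapiens) for antiproliferative activity, read by MTT assay, with a stated time of 72 h (a lower number here means a stronger inhibitor, a higher number a weaker inhibitor), compound 1 (`CCOc1ccc(-c2ncnn2-c2cc(OC)c(OC)c(OC)c2)cc1Cl`) gives 3 nM. Compound 2 (`COc1cc(-n2ncnc2-c2ccc(OC(F)(F)F)cc2)cc(OC)c1OC`) gives > 10000 nM, which is a limit of the assay and not a number. Compound 3 (`COc1cc(-n2ncnc2-c2ccc(Cl)c(Cl)c2)cc(OC)c1OC`) gives > 10000 nM, again a limit and not a number. Compound 3 therefore offers no true starting value, only (the limit of > 10000 nM in this assay, at which 2 of the 3 values shown sit).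

Compound 4 (`COc1cc(-n2ncnc2-c2ccc(SC)cc2)cc(OC)c1OC`) differs from compound 3 in one group: 4-(methylsulfanyl)phenyl in place of 3,4-dichlorophenyl on an aromatic carbon. For the measured compounds named here, the one measured step that bears on this change is an at least 3300-fold higher number from compound 1 to compound 3 (3.52 log units; beyond the scatter), and it is large. Compound 4 has no chloro, and like compound 1, with its 3 nM, it carries a small chain on the aryl group, here methylsulfanyl rather than ethoxy. Compound 2 goes against this reading: it also has no chloro and carries a chain of its own, yet shows only a limit. A large move toward a lower number in this assay is therefore expected, but it is far from certain, and compound 4 may stay at the limit. The expected change is an at least 33-fold lower number from compound 3 to compound 4 (1.52 log units; beyond the scatter). For compound 4 the estimate is 300 nM, with an expected range from 15 nM to 10000 nM.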

Compound 4, half-maximal inhibitory concentration: 50 nM
For compound 4 the middle estimate is 6.0-fold (0.78 log units) above the measured one; the range from low to high includes it.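

Exchanging 3,4-dichlorophenyl for 4-(methylsulfanyl)phenyl on this aromatic carbon, with the rest of the molecule unchanged, gives an at least 200-fold lower number from compound 3 to compound 4 (2.30 log units; beyond the scatter) in this assay, so the aryl group here alone can carry a compound from the limit of the assay to a measured value. The chain on that aryl group matters as well, since methylsulfanyl in place of trifluoromethoxy gives an at least 200-fold lower number from compound 2 to compound 4 (2.30 log units; beyond the scatter), which shows that carrying a small chain is not enough and that the identity of the chain counts. Both steps start from a limit and not from a number, so they give only a lower bound on the true size of the change: the limit of > 10000 nM in this assay, at which 2 of the 4 values shown sit.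

Going by these compounds, what stays open is whether the chloro of compound 1 would add anything to the aryl group of compound 4, and whether the sulfur itself counts, which a methoxy or ethylsulfanyl chain in place of methylsulfanyl would tell. Also open, on these data alone, is how an amine or a carboxylic acid on this aryl group would fare in this assay.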